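Cyclopropylamino purine series: side-chain amide variant

A few compounds are considered here, and "the series" means these few. Any claim that something is new, unique, unknown or untested is made for them only; others in the source may bear on it.

Compound 1 `Clc1nc(NC2CC2)c2ncn(C3CCCCO3)c2n1` gives 11.9% in a functional assay on the whole organism with Mus musculus as the target, with a stated time of 90 min, at a dose of 25 umol/kg by the oral route; on this read-out higher numbers stand for a stronger effect at the one dose given and lower numbers for a weaker effect. For the measured compounds named here, compound 2 `CCOC(=O)CN(c1nc(Cl)nc2c1ncn2C1CCCCO1)C1CC1` gives 13% in this assay, and the only single-place step measured so far, a number 1.1 percentage points higher from compound 1 to compound 2 (within the scatter), stays within the scatter. Going by the values given here, compound 3 `N=C(N)NCCC[C@H](NC(=O)CN(c1nc(Cl)nc2c1ncn2C1CCCCO1)C1CC1)C(=O)OCc1ccccc1` gives 61.6% in this assay and stands highest of the three, beyond the scatter from both compound 2 and compound 1; the gap between compound 2 and compound 3 spans more than one structural place, so no single step is drawn from it.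

Compound 4 `NC(=O)CC[C@H](NC(=O)CN(c1nc(Cl)nc2c1ncn2C1CCCCO1)C1CC1)C(=O)OCc1ccccc1` differs from compound 3 by a group of 3 heavy atoms (1 carbon, 1 nitrogen, 1 oxygen; no ring) in place of a group of 5 heavy atoms (2 carbon, 3 nitrogen; no ring), on a saturated chain carbon, three bonds along the chain from an amide-type nitrogen and a carbonyl carbon. Among the compounds with values here, no measured step touches this position or this kind of exchange; the one step on record concerns a different site and was within the scatter, so it gives no direction here. The estimate therefore leans on compound 3 alone, allowing for some loss, and the expected step is a number 19.6 percentage points lower from compound 3 to compound 4 (beyond the scatter). Compound 4 is expected to give about 42% in this assay, between 15% and 65%.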

Compound 4, a percentage reported as activity, at one dose (the size of the read-out at that dose, not a potency): 37.8%
Compound 4: the middle estimate sits 4.2 percentage points above what was measured; measured number inside the range.
By their numbers in this assay, from the lowest: compounds 1 and 2 (each within the scatter of the next); then compound 4; then compound 3.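

For the compounds shown here, with carbamoyl in place of the group of 5 heavy atoms on the saturated chain carbon, this assay gives a number 23.8 percentage points lower from compound 3 to compound 4 (beyond the scatter) and so provides the first measured exchange at this position. Going by these compounds alone, the read-out therefore responds to what this chain carbon carries, which the one earlier step could not show, as it concerned a different site and stayed within the scatter. No measurement at hand bears on the reason for this step.

On these data alone, it remains open whether an amine, a carboxylic acid or a longer chain on this same carbon would give a number closer to that of compound 3 or to that of compound 4. Also open, as far as these compounds go, is whether the carbamoyl exchange would produce a step of similar size with a carboxylic acid in place of the ester.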